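The source may hold more compounds than are shown below. What is called first, only, known or untested is meant among the compounds shown, and "the series" means these compounds.

Measured so far:

compound 1, `CO/C(O)=C1\C(C)=NC(C)=C(C(=O)OCCCN2C(=O)c3ccccc3S2(=O)=O)C1c1ccccc1[N+](=O)[O-]`, 120 nM
compound 2, `CC1=NC(C)=C(C(=O)OCN2C(=O)c3ccccc3S2(=O)=O)C(c2ccccc2[N+](=O)[O-])/C1=C(\O)OCC1CCCO1`, 286 nM
compound 3, `COCCO/C(O)=C1\C(C)=NC(C)=C(C(=O)OCCCN2C(=O)c3ccccc3S2(=O)=O)C1c1ccccc1C(F)(F)F`, 21.8 nM

All three numbers come from a functional assay for inhibition, with Oryctolagus cuniculus as the target; a lower number here means a stronger inhibitor, a higher number a weaker inhibitor. Among them compound 1 holds the second highest number. Its nearest neighbour is compound 2, whose number is higher by more than the usual scatter of repeated measurements, so compound 2 reads as the weaker inhibitor of the two. Compound 3 lies furthest from compound 1, with a lower number, again beyond the scatter, and is therefore the stronger inhibitor of the pair. No two of these compounds differ in only one place, so no single change can be tied to a step.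

Compound 4, `CO/C(O)=C1\C(C)=NC(C)=C(C(=O)OCCCN2C(=O)c3ccccc3S2(=O)=O)C1c1ccccc1Cl`, has not yet been measured. It differs from compound 1 in one respect: chloro in place of nitro on an aromatic carbon. Among the measured compounds shown here, with no comparable pair among the measured compounds, the step in this assay is expected to be small, not clearly beyond the scatter in either direction; the estimated step is a 1.1-fold lower number from compound 1 to compound 4 (0.04 log units; within the scatter). Compound 4 is therefore expected to give about 110 nM, in a range from 40 nM to 300 nM.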

Compound 4, half-maximal inhibitory concentration: 140 nM
The estimate for compound 4 lay 1.3-fold (0.10 log units) below the measured number; the range from low to high includes it.
By their numbers in this assay, from the lowest: compound 3; then compounds 1 and 4 (each within the scatter of the next); then compound 2.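

Compounds 1 and 4 form the only pair shown that differs in one place, so one change can be read here by itself. In this assay, replacing nitro with chloro on an aromatic carbon, ortho to a large group, gives a 1.2-fold higher number from compound 1 to compound 4 (0.07 log units; within the scatter), so the two compounds cannot be told apart. At this position of this core, the 2-nitrophenyl and 2-chlorophenyl forms therefore read alike, even though nitro has 3 heavy atoms and 2 hydrogen-bond acceptors, while chloro has 1 heavy atom and no such acceptors. Nothing measured here explains why these two groups read alike.

Going by these compounds, whether an amine, a methoxy group or a carboxylic acid on the same aromatic carbon would read the same remains open. Also open, on these data alone, is what trifluoromethyl does at this position, since compound 3 carries it but differs from compound 1 in another place too.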